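Aryl exchange on the carbonyl carbon: expectation for compound 4

The source may hold more compounds than are shown below. What is called first, only, known or untested is meant among the compounds shown, and "the series" means these compounds.

Measured so far, in an assay on cells for agonist activity at ecdysone receptor (Bombyx mori), read by a luciferase reporter, with a stated time of 24 h; on this read-out higher numbers stand for an effect only at larger amounts of compound and lower numbers for an effect already at smaller amounts:
compound 1 `CCc1ccccc1C(=O)N(NC(=O)c1ccccc1)C(C)(C)C` gives 589 nM
compound 2 `CC(C)(C)N(NC(=O)c1ccccc1I)C(=O)c1ccccc1Cl` gives 1290 nM
compound 3 `CC(C)(C)N(NC(=O)c1cccc(F)c1)C(=O)c1ccccc1Cl` gives 69.2 nM

Compound 3 stands lowest of the three numbers in this assay. The nearest is compound 1, whose number is higher by more than the scatter, and the furthest is compound 2, higher still. Among the compounds with values here, only one measured step changes the aryl group on the same carbonyl carbon, and it is large: a 19-fold lower number from compound 2 to compound 3 (1.27 log units; beyond the scatter). Within the data shown here, that step shows that the kind and placement of a halogen on this ring can move the number by a wide margin, but no measured compound carries a 4-chlorophenyl, so neither direction nor size of the next change is pinned down by data.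

Compound 4 `CC(C)(C)N(NC(=O)c1ccc(Cl)cc1)C(=O)c1ccccc1Cl` is compound 3 with one change: 4-chlorophenyl in place of 3-fluorophenyl on a carbonyl carbon. Given that compound 3 already gives 69.2 nM and that compound 1, without halogen, gives 589 nM, a 4-chlorophenyl is expected to land between those two, a step of a 2.9-fold higher number from compound 3 to compound 4 (0.46 log units; beyond the scatter) upward. For compound 4 the number expected in this assay is 200 nM, with a range from 40 nM to 1000 nM; the range is broad because the step of a 19-fold lower number from compound 2 to compound 3 (1.27 log units; beyond the scatter) shows how strongly this ring responds to halogen changes.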

Compound 4, half-maximal effective concentration: 115 nM
Beside the measured number, compound 4's estimate is 1.7-fold (0.24 log units) above it; measured number inside the range.
By their numbers in this assay, from the lowest: compounds 3 and 4 (each within the scatter of the next); then compound 1; then compound 2.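

In this assay, exchanging 3-fluorophenyl for 4-chlorophenyl on the carbonyl carbon gives a 1.7-fold higher number from compound 3 to compound 4 (0.22 log units; within the scatter), so this change does not separate the two groups, although both the halogen and its place in the group's name differ. The comparison with 2-iodophenyl gives an 11-fold lower number from compound 2 to compound 4 (1.05 log units; beyond the scatter), showing that the large distance of compound 2 from compound 3 is not confined to the 3-fluorophenyl group: among these three aryl groups on an otherwise shared core, only the 2-iodophenyl of compound 2 stands apart. No evidence on hand accounts for this pattern.

Halogen and placement changed together from compound 3 to compound 4, so their separate contributions at this carbonyl carbon remain unresolved. Also open, from the compounds shown here alone, is how this position responds to a plain phenyl or to a ring carrying a methoxy group, an amine or a carboxylic acid, which would show whether a halogen is needed here at all.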